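This account rests on a few compounds, and the source may have more. Where it says the series, first, only, none or still open, it means among the compounds named here.

Measured compounds:
Compound 1, `NC1=NC2(CCSCC2)N(OCCCOc2cccc(Cl)c2)C(N)=N1`, in a functional assay on HepG2 cells (Homo sapiens) for antiproliferative activity, read by MTT assay, with a stated time of 72 h (on this read-out higher numbers stand for weaker inhibition and lower numbers for stronger inhibition), compound 1 gives 90 nM.
Compound 2, `NC1=NC2(CCSCC2)N(OCCCOc2ccc(Cl)cc2)C(N)=N1`, in this assay compound 2 gives 1100 nM.
Compound 3, `NC1=NC2(CCOCC2)N(OCCCOc2ccc(Cl)cc2Cl)C(N)=N1`, in this assay compound 3 gives "not determined" (no result reported).

Among the compounds with values here, compound 2 stands at the highest of the two numbers known here; its nearest neighbour is compound 1, and the step of a 12-fold higher number from compound 1 to compound 2 (1.09 log units; beyond the scatter) lies beyond the scatter, so compound 2 is the weaker of the two measured compounds. Compound 4, `COc1ccc(OCCCON2C(N)=NC(N)=NC23CCSCC3)cc1`, is not yet measured. It differs from compound 2 in one place: methoxy in place of chloro on an aromatic carbon.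

None of the measured steps concerns a methoxy in place of chloro; the only step shown, a 12-fold higher number from compound 1 to compound 2 (1.09 log units; beyond the scatter), moves the chloro between positions and says nothing about swapping it for another group. Within the data shown here, with no directly bearing step, the account cannot point to a change beyond the scatter in either direction. Compound 4 is therefore expected to sit near compound 2, with the step of a 1.4-fold higher number from compound 2 to compound 4 (0.13 log units; within the scatter) expected to be small. The estimate for compound 4 in this assay is 1500 nM, within a range from 450 nM to 5000 nM.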

Compound 4, half-maximal inhibitory concentration: 880 nM
Compound 4: middle estimate off by 1.7-fold (0.23 log units), on the high side; low and high end bracket the measured number.
By their numbers in this assay, from the lowest: compound 1; then compounds 4 and 2 (each within the scatter of the next).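

In this assay, the earlier compounds had only shown the chlorine changing place, whereas here the group itself changes on the aromatic carbon para to a large group. Methoxy in place of chloro gives a 1.3-fold lower number from compound 2 to compound 4 (0.10 log units; within the scatter), so the two groups cannot be told apart at this place. The step of a 9.8-fold higher number from compound 1 to compound 4 (0.99 log units; beyond the scatter) shows that the 4-methoxyphenyl compound, like the 4-chlorophenyl compound, remains apart from the 3-chlorophenyl compound, and nothing measured here bears on the cause of these results.

From the compounds shown here alone, it remains open whether a methoxy on the ring carbon that holds the chlorine in compound 1 would match compound 1. Going by these compounds, it is also open whether an amine or a carboxylic acid in place of the chloro of compound 2 would shift the number beyond the scatter.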